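From a Methoxymethyl to a Cyclopropyl Group

A few compounds are considered here, and "the series" means these few. Any claim that something is new, unique, unknown or untested is made for them only; others in the source may bear on it.

Of the compounds shown here, three have been measured in an assay for binding affinity to Corticotropin releasing factor receptor (Rattus norvegicus); a lower number here means a stronger inhibitor, a higher number a weaker inhibitor. Compound 1 `CCCC(C)n1c(CC)nc2c(-c3ccc(OC)cc3C)ccnc21` gives 0.8 nM, compound 3 `CCCC(C)n1c(CC)nc2c(-c3ccc(C(C)(C)O)cc3Cl)ccnc21` gives 24 nM, and compound 2 `CCC(CCOC)n1c(COC)nc2c(-c3ccc(C(F)(F)F)cc3Cl)ccnc21` gives 82.7 nM. Compound 2 thus stands with the highest number of the three, beyond the scatter from both others, making it the weakest inhibitor among them. Compound 4 `CCC(CCOC)n1c(C2CC2)nc2c(-c3ccc(C(F)(F)F)cc3Cl)ccnc21` differs from compound 2 in one place: cyclopropyl in place of methoxymethyl on an aromatic carbon. For the measured compounds named here, no measured pair shows this change, so its effect remains unknown. A modest move toward a lower number is expected, though it may not exceed the scatter. The step from compound 2 to compound 4 is expected to be a 2.1-fold lower number from compound 2 to compound 4 (0.32 log units; beyond the scatter). For compound 4 the expected value in this assay is 40 nM, within a range from 10 nM to 150 nM.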

Compound 4, inhibition constant: 20.8 nM
Beside the measured number, compound 4's estimate is 1.9-fold (0.28 log units) above it, and the stated range covers the measured number.
By their numbers in this assay, from the lowest: compound 1; then compounds 4 and 3 (each within the scatter of the next); then compound 2.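

On this aromatic carbon between two ring nitrogen atoms, cyclopropyl in place of methoxymethyl gives a 4.0-fold lower number from compound 2 to compound 4 (0.60 log units; beyond the scatter) in this assay. The swap keeps the heavy-atom count, yet it removes the oxygen and its hydrogen-bond acceptor and adds a ring, so this position responds to the identity of the group and not only to its heavy-atom count. Nothing available explains why the number falls. As far as these compounds go, whether a cyclobutyl group or a propyl chain here would lower the number further remains open. So does whether cyclopropyl would give a similar step in compound 1 or compound 3.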